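A Methyl Branch on the Propyl Amide Chain

This account rests on a few compounds, and the source may have more. Where it says the series, first, only, none or still open, it means among the compounds named here.

Three compounds sharing one core were tested in a functional assay on A549 cells (Homo sapiens) for cytotoxicity, read by MTT assay, with a stated time of 24 h; on this read-out higher numbers stand for weaker inhibition and lower numbers for stronger inhibition. Compound 1, `C=CC1=C(C(=O)O)C(c2ccc(OC)cc2)OC1`, carries a carboxylic acid; in this assay compound 1 gives > 100000 nM, which is a limit of the assay rather than a number. Compound 2, `C=CC1=C(C(=O)Nc2ccccc2)C(c2ccc(OC)cc2)OC1`, carries an anilide instead; in this assay compound 2 gives > 100000 nM, again a limit. Compound 3, `C=CC1=C(C(=O)NCCC)C(c2ccc(OC)cc2)OC1`, carries a propylamide; in this assay compound 3 gives > 100000 nM, once more a limit. Because (the limit of > 100000 nM in this assay, at which 3 of the 3 values shown sit), every step between the three stays unreadable: a step that the two limits leave unreadable from compound 1 to compound 2, a step that the two limits leave unreadable from compound 1 to compound 3 and a step that the two limits leave unreadable from compound 2 to compound 3. Compound 3 thus stands at the limit shared by all values shown, with nothing to separate it from the other two.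

Compound 4, `C=CC1=C(C(=O)NCC(C)C)C(c2ccc(OC)cc2)OC1`, differs from compound 3 by methyl in place of hydrogen on a saturated chain carbon bound to two saturated chain carbons. Going by the values given here, no measured step bears on this change in a readable way, since all three values sit at the limit. Compound 4 is therefore expected to remain at that same limit. This expectation means a step that the limit leaves unreadable from compound 3 to compound 4. The estimate for compound 4 is 150000 nM, with a range from 50000 nM to 500000 nM.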

Compound 4, half-maximal inhibitory concentration: > 100000 nM
Compound 4: no number, only a limit (the forecaster's own chance of this, stated with the estimate: 85%); the middle value lies beyond the limit too.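

No step between compound 4 and compound 1, compound 2 or compound 3 can be read, since all four compounds sit at one limit and give no number to compare: the limit of > 100000 nM in this assay, at which 4 of the 4 values shown sit.

The compounds shown leave open how strongly any of them inhibits these cells, and whether the methyl branch of compound 4 changes that at all.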